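Half-life expected for compound 4 in mouse liver microsomes

The source may report more compounds than this note shows. Statements on the series, on what has been measured and on what is new or still open speak of the compounds shown alone.

Compound 1, `CC(C)C(c1ncc[nH]1)c1ccc(-c2ccc3cccc(F)c3c2)[nH]c1=O`: in an ADME assay on microsomes from liver (Mus musculus) for metabolic stability (a lower number here means that the compound disappears faster, a higher number that the compound lasts longer), compound 1 gives < 0.0667 h, which is a limit of the assay.
Compound 2, `CC(C)C(c1ccc(-c2ccc3cccc(F)c3c2)[nH]c1=O)N1CCCCC1=O`: in this assay compound 2 gives 0.0967 h.
Compound 3, `CC(C)C(Nc1nccs1)c1ccc(-c2ccc3cccc(F)c3c2)[nH]c1=O`: in this assay compound 3 gives 0.0733 h.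

Compound 3 and compound 2 lie within the scatter of each other, the step being a 1.3-fold lower number from compound 2 to compound 3 (0.12 log units; within the scatter). Compound 1 reports only a limit (the limit of < 0.0667 h in this assay, at which 1 of the 3 values shown sits). The steps of an at least 1.0-fold higher number from compound 1 to compound 3 (0.04 log units; that floor lies within the scatter) and an at least 1.4-fold higher number from compound 1 to compound 2 (0.16 log units; that floor lies within the scatter) are therefore known only as floors. Compound 4, `CC(C)C(c1ccc(-c2ccc3cccc(F)c3c2)[nH]c1=O)N1CCN/C1=N\C#N`, differs from compound 3 by a group of 8 heavy atoms (4 carbon, 4 nitrogen; one five-membered non-aromatic ring with 2 hetero atoms) in place of a group of 6 heavy atoms (3 carbon, 2 nitrogen, 1 sulfur; one five-membered aromatic ring with 2 hetero atoms), on a saturated chain carbon bound to an aromatic carbon and a saturated chain carbon. All three measured steps exchange the group on this same carbon, and none is shown to reach beyond the scatter, so no step beyond the scatter is expected in this assay for compound 4. Compound 4 is expected to give 0.08 h, within 0.04 h to 0.17 h. This corresponds to an expected step of a 1.1-fold higher number from compound 3 to compound 4 (0.04 log units; within the scatter).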

Compound 4, half-life: 0.207 h
Compound 4: the middle estimate sits 2.6-fold (0.41 log units) below what was measured, and the stated range ends below it.
By their numbers in this assay, from the lowest: compounds 3 and 2 (each within the scatter of the next); then compound 4. At a limit, below all of these: compound 1.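

The steps of a 2.8-fold higher number from compound 3 to compound 4 (0.45 log units; beyond the scatter) and a 2.1-fold higher number from compound 2 to compound 4 (0.33 log units; beyond the scatter) are the first on this saturated chain carbon shown to reach beyond the scatter in this assay, so the group exchanged here can move the half-life measurably. Of the groups shown at this place, the five-membered non-aromatic ring carrying a nitrile gives the longest half-life. The remaining step, an at least 3.1-fold higher number from compound 1 to compound 4 (0.49 log units; beyond the scatter), is only a floor, set by a limit: the limit of < 0.0667 h in this assay, at which 1 of the 4 values shown sits.

Whether the ring or the nitrile accounts for the gain stays open. The same ring with a carbonyl in place of the nitrile-bearing group would separate the two, and a morpholine would test another ring at this carbon.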